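The source may hold more compounds than are shown below. What is called first, only, known or untested is meant among the compounds shown, and "the series" means these compounds.

Working notes on the series

Compound 1 `FC(F)(F)c1ccc(COc2cccc(Nc3ncnc4cc5c(cc34)OCCOCCOCCOCCO5)c2)cc1` and compound 2 `FC(F)(F)c1ccc(COc2ccc(Nc3ncnc4cc5c(cc34)OCCOCCOCCOCCO5)cc2)cc1` are built from the same atoms joined differently; the difference between the two cores is not broken down here. In a functional assay on A549 cells (Homo sapiens) for antiproliferative activity, read by MTT assay, with a stated time of 72 h (a lower number here means a stronger inhibitor, a higher number a weaker inhibitor), compound 1 gives 8520 nM, and compound 2 gives 8560 nM; the two numbers lie within the scatter of each other.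

Compound 3 `O=[N+]([O-])c1ccc(COc2cccc(Nc3ncnc4cc5c(cc34)OCCOCCOCCOCCO5)c2)cc1` derives from compound 1 by nitro in place of trifluoromethyl on an aromatic carbon. In this assay compound 3 gives 19800 nM, which is a 2.3-fold higher number from compound 1 to compound 3 (0.37 log units; beyond the scatter).

Compound 4 `O=[N+]([O-])c1ccc(COc2ccc(Nc3ncnc4cc5c(cc34)OCCOCCOCCOCCO5)cc2)cc1` has not yet been measured. It differs from compound 2 by nitro in place of trifluoromethyl on an aromatic carbon, the same change as from compound 1 to compound 3, at a place described in the same words.

The step into compound 4 in this assay is expected to be of about the size seen earlier, because compound 2 starts from 8560 nM, a value within the scatter of compound 1, and because the earlier step was a 2.3-fold higher number from compound 1 to compound 3 (0.37 log units; beyond the scatter). Compound 4 is therefore expected to give 19700 nM, with a range from 11000 nM to 36000 nM, an expected step of a 2.3-fold higher number from compound 2 to compound 4 (0.36 log units; beyond the scatter).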

Compound 4, half-maximal inhibitory concentration: > 100000 nM
Compound 4 was reported as a limit; the forecaster's own chance of this, stated with the estimate: 5%; middle value at least 5.0-fold (0.70 log units) from the limit.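

In this assay compound 4 is reported only as a limit, > 100000 nM, and not as a number. Nitro in place of trifluoromethyl still gives an at least 11-fold higher number from compound 2 to compound 4 (1.06 log units; beyond the scatter), so on these two cores the change raises the number both times but does not carry over at one size: the same change on two cores in this assay, a 2.3-fold higher number (0.37 log units; beyond the scatter) from compound 1 to compound 3 and an at least 11-fold higher number (1.06 log units; beyond the scatter) from compound 2 to compound 4, at least 5.0-fold (0.70 log units) apart, beyond the scatter of two such steps. This does not show how large the step on the core of compound 2 really is, why the two cores part, or how the change would behave on any third core, and the size stays bounded on one side only, as the value sits at the limit: the limit of > 100000 nM in this assay, at which 1 of the 4 values shown sits.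

Still open, on these data alone, is whether this gap belongs to nitro alone, which a nitrile or an amine on the same aromatic carbon, read on both cores, could begin to settle. Also open, as far as these compounds go, is whether a further core would follow the step into compound 3 or the step into compound 4.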